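Swapping a Methyl for an Oxane Ring on the Core

The compounds below may be only part of what the source reports. "The series", "measured", "known", "first", "only" and "open" are said of these compounds alone.

Measured compounds:
Compound 1 `CC(C)(O)Cn1nc(-c2cc(C3CC3)on2)c2c(N)ncnc21`: 4250 nM
Compound 2 `Cn1nc(-c2cc(C3CC3)on2)c2c(N)ncnc21`: 3510 nM

Of the compounds shown here, two have been measured in an assay on TT cells for inhibition of proto-oncogene tyrosine-protein kinase receptor Ret variant C634W (Homo sapiens), read by MTT assay, with a stated time of 10 days; a lower number here means a stronger inhibitor of growth, a higher number a weaker inhibitor of growth. Compound 1 gives 4250 nM, and compound 2 gives 3510 nM. Compound 2 holds the lower of the two numbers, but the step of a 1.2-fold lower number from compound 1 to compound 2 (0.08 log units; within the scatter) lies within the scatter, so the two compounds cannot be told apart on these data.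

Compound 3 `Nc1ncnc2c1c(-c1cc(C3CC3)on1)nn2C1CCOCC1` has not yet been measured. It differs from compound 2 by oxan-4-yl in place of methyl on an aromatic nitrogen. Within the data shown here, the one measured step, a 1.2-fold lower number from compound 1 to compound 2 (0.08 log units; within the scatter), removed a sizeable group from a chain carbon attached to that same aromatic nitrogen and stayed within the scatter. Compound 3 is therefore expected to show a step of a 1.2-fold lower number from compound 2 to compound 3 (0.07 log units; within the scatter) that stays small. Compound 3 is estimated at 3000 nM, with a range from 800 nM to 11000 nM.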

Compound 3, concentration for 50% growth inhibition: 940 nM
Compound 3: middle estimate off by 3.2-fold (0.50 log units), on the high side; measured number inside the range.
By their numbers in this assay, from the lowest: compound 3; then compounds 2 and 1 (each within the scatter of the next).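

In this assay, the group on this aromatic nitrogen can shift the number after all: replacing methyl with oxan-4-yl gives a 3.7-fold lower number from compound 2 to compound 3 (0.57 log units; beyond the scatter), whereas the earlier change at this nitrogen stayed within the scatter. Replacing 2-hydroxy-2-methylpropyl with oxan-4-yl gives a 4.5-fold lower number from compound 1 to compound 3 (0.66 log units; beyond the scatter), so this ring stands apart from both other groups tested here, although both steps are modest. Nothing measured here gives a reason for this gain.

Going by these compounds, what stays open is whether the lower number goes with the six-membered ring as such or with its oxygen: a cyclohexyl group, or a piperidin-4-yl group with a nitrogen in place of that oxygen, would help separate the two. Also open, on these data alone, is how a smaller ring, such as cyclopropyl or oxetan-3-yl, would read at this nitrogen.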